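Replacing a chlorophenyl with a nitrophenyl: expected cytotoxicity

The source may report more compounds than this note shows. Statements on the series, on what has been measured and on what is new or still open speak of the compounds shown alone.

Compound 1, `COc1cc(CC(O)c2ccc(-c3ccc(CO)cc3)cc2)c([N+](=O)[O-])cc1OC`, gives only a limit in an ADME assay on HeLa Rh cells (Homo sapiens) for cytotoxicity, read by microscopy; on this read-out higher numbers stand for lower toxicity in this test and lower numbers for higher toxicity in this test: > 244000 nM.
Compound 2, `COc1cc(CC(O)c2ccc(-c3ccc(Br)cc3)cc2)c([N+](=O)[O-])cc1OC`, gives 4300 nM in this assay.
Compound 3, `COc1cc(CC(O)c2ccc(-c3cccc(Cl)c3)cc2)c([N+](=O)[O-])cc1OC`, gives 5900 nM in this assay.

Compound 3 and compound 2 give numbers that cannot be told apart, as the step of a 1.4-fold higher number from compound 2 to compound 3 (0.14 log units; within the scatter) shows. Compound 1 stands far from both: the steps of an at least 41-fold lower number from compound 1 to compound 3 (1.61 log units; beyond the scatter) and an at least 56-fold lower number from compound 1 to compound 2 (1.75 log units; beyond the scatter) are large, and the value of compound 1 is a limit, so the true gap may be wider still.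

Compound 4, `COc1cc(CC(O)c2ccc(-c3ccccc3[N+](=O)[O-])cc2)c([N+](=O)[O-])cc1OC`, differs from compound 3 in one place: 2-nitrophenyl in place of 3-chlorophenyl on an aromatic carbon. Among the measured compounds shown here, two measured steps bear on this change. Swapping one halogen-bearing phenyl for another, the step of a 1.4-fold higher number from compound 2 to compound 3 (0.14 log units; within the scatter), changed nothing beyond the scatter; exchanging a phenyl carrying a hydroxymethyl for a chlorophenyl, the step of an at least 41-fold lower number from compound 1 to compound 3 (1.61 log units; beyond the scatter), moved the number a great deal. A nitrophenyl is neither a halophenyl nor a hydroxymethylphenyl, so the outcome is uncertain and a moderate rise is the best guess. Compound 4 is therefore expected to give 15000 nM in this assay, with a range from 4000 nM to 80000 nM. The estimated step is a 2.5-fold higher number from compound 3 to compound 4 (0.41 log units; beyond the scatter).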

Compound 4, half-maximal cytotoxic concentration: 9500 nM
The estimate for compound 4 lay 1.6-fold (0.20 log units) above the measured number; the range from low to high includes it.
By their numbers in this assay, from the lowest: compounds 2, 3 and 4 (each within the scatter of the next, the first and the last beyond it). At a limit, above all of these: compound 1.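

On this aromatic carbon, 2-nitrophenyl carries no halogen, yet in this assay it stays close to the halogen-bearing rings: the step of a 1.6-fold higher number from compound 3 to compound 4 (0.21 log units; within the scatter) is within the scatter, and the step of a 2.2-fold higher number from compound 2 to compound 4 (0.34 log units; beyond the scatter) is only modest. A halogen on this ring is therefore not required for a number in this range, and among the four compounds only the 4-(hydroxymethyl)phenyl ring stands apart, as the large step of an at least 25-fold lower number from compound 1 to compound 4 (1.40 log units; beyond the scatter) shows. Compound 1 gives only a limit: the limit of > 244000 nM in this assay, at which 1 of the 4 values shown sits.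

From the compounds shown here alone, it remains open whether a phenyl ring carrying an amine, a carboxylic acid or a longer chain ending in a hydroxyl would move the number as far as hydroxymethyl does. The compounds shown also do not tell whether a nitro group elsewhere on that phenyl ring would give a similar number.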